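The source may report more compounds than this note shows. Statements on the series, on what has been measured and on what is new or still open speak of the compounds shown alone.

Compound 1 `N=c1scc(-c2ccccc2)n1CC(=O)N1CCOCC1` is the reference point of this small set. In an assay on isolated protein for inhibition of vitamin D3 receptor (Homo sapiens) (a higher number here means a weaker inhibitor, a lower number a stronger inhibitor), compound 1 gives 24400 nM, the second highest of the three numbers recorded. Its nearest neighbour is compound 2 `CN1CCN(C(=O)Cn2c(-c3ccccc3)csc2=N)CC1`, which gives 28300 nM; the step of a 1.2-fold higher number from compound 1 to compound 2 (0.06 log units; within the scatter) shows that exchanging the amine on the carbonyl carbon leaves the number where it was. The furthest is compound 3 `N=c1scc(-c2ccc(Cl)cc2)n1CC(=O)N1CCN(c2ccccc2)CC1`, which gives 3070 nM; compound 3 differs from compound 1 in two places at once, so its lower number cannot be assigned to either change on its own.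

Compound 4 `N=c1scc(-c2ccc(Cl)cc2)n1CC(=O)N1CCOCC1` is the next member to be measured. It differs from compound 1 by chloro in place of hydrogen on an aromatic carbon. Among the measured compounds shown here, no measured step isolates this change. For the measured compounds named here, the one step that is known, a 1.2-fold higher number from compound 1 to compound 2 (0.06 log units; within the scatter), concerns the amine end and bears on it only indirectly. The pair compound 1 and compound 3 shows that a compound carrying the chloro group together with a different amine comes out lower, but that comparison does not separate the two changes. The expectation is therefore a modest move downward, a 2.0-fold lower number from compound 1 to compound 4 (0.31 log units; beyond the scatter), with wide uncertainty. Compound 4 is estimated at 12000 nM, within 4000 nM to 35000 nM.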

Compound 4, inhibition constant: 4130 nM
Compound 4: the middle estimate sits 2.9-fold (0.46 log units) above what was measured; low and high end bracket the measured number.
By their numbers in this assay, from the lowest: compounds 3 and 4 (each within the scatter of the next); then compounds 1 and 2 (each within the scatter of the next).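

In this assay, the step of a 5.9-fold lower number from compound 1 to compound 4 (0.77 log units; beyond the scatter) isolates the change from phenyl to 4-chlorophenyl and places it beyond the scatter, so chloro in place of hydrogen, on an aromatic carbon para to a large group, moves the number on its own. With the chloro group held constant, compound 4 gives 4130 nM and compound 3 gives 3070 nM; these two values lie within the scatter of each other, so exchanging the amine on the carbonyl carbon leaves no readable change in this pair. Among the four compounds, the aromatic position is therefore the only place where a single change gives a step beyond the scatter, while both single changes of the amine, in the pair compound 1 and compound 2 and in the pair compound 3 and compound 4, stay within it.

Nothing in the data explains why the chloro group shifts the number. Also open, on these data alone, is whether fluoro, methyl, methoxy or nitrile in the same place would give a similar step, and whether the 4-methylpiperazin-1-yl amide of compound 2 would respond to chloro as the morpholin-4-yl amide of compound 1 does.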